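Trifluoromethyl in place of methoxy: expecting compound 4

The compounds below may be only part of what the source reports. "The series", "measured", "known", "first", "only" and "open" are said of these compounds alone.

Measured in a functional assay on MCF7 cells (Homo sapiens) for antiproliferative activity, with a stated time of 5 days; a higher number here means a weaker inhibitor, a lower number a stronger inhibitor:
Compound 1 `CCCCc1ccc2[nH]c(-c3ccc(C(F)(F)F)cc3)c(C=O)c2c1`: 66 nM
Compound 2 `CCCCc1ccc2[nH]c(-c3ccc(C(F)(F)F)cc3)c(/C=N\C)c2c1`: 140 nM
Compound 3 `CCCCc1ccc2[nH]c(-c3ccc(OC)cc3)c(/C=N\O)c2c1`: 212 nM

Compound 3, at 212 nM, lies beyond the scatter above compound 1 and within the scatter of compound 2. Compound 4 `CCCCc1ccc2[nH]c(-c3ccc(C(F)(F)F)cc3)c(/C=N\O)c2c1` follows from compound 3 by one change: trifluoromethyl in place of methoxy on an aromatic carbon, which is trifluoromethyl in place of methoxy on an aromatic carbon. Among the compounds with values here, no measured step covers this change directly. Within the data shown here, the only step, a 2.1-fold higher number from compound 1 to compound 2 (0.33 log units; beyond the scatter), is modest and concerns another place, with trifluoromethyl kept. Compound 2, which carries trifluoromethyl, gives 140 nM, so the data offer no hint of a large shift. The expected step is small, towards a lower number: a 1.4-fold lower number from compound 3 to compound 4 (0.15 log units; within the scatter). For compound 4 the estimate is 150 nM, with an expected range of 50 nM to 450 nM.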

Compound 4, half-maximal inhibitory concentration: 1660 nM
For compound 4 the middle estimate is 11-fold (1.04 log units) below the measured one; the measured number lies above the stated range.
By their numbers in this assay, from the lowest: compound 1; then compounds 2 and 3 (each within the scatter of the next); then compound 4.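

In this assay, the aromatic position proves sensitive when hydroxy sits on the double-bonded nitrogen: trifluoromethyl in place of methoxy gives a 7.8-fold higher number from compound 3 to compound 4 (0.89 log units; beyond the scatter). With trifluoromethyl kept, the group at the other place matters far more than the earlier step suggested, with hydroxy in place of methyl giving a 12-fold higher number from compound 2 to compound 4 (1.07 log units; beyond the scatter) and the replacement of the carbonyl group giving a 25-fold higher number from compound 1 to compound 4 (1.40 log units; beyond the scatter). Nothing available explains these steps. From the compounds shown here alone, it remains open whether methoxy would matter equally alongside the carbonyl group of compound 1, and how an amine or a carboxylic acid would fare at the aromatic position.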